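A few compounds are considered here, and "the series" means these few. Any claim that something is new, unique, unknown or untested is made for them only; others in the source may bear on it.

Compound 1 `COc1ccc(/C=N/NC(=O)Nc2ccc(Oc3ccnc(-c4nncn4CCN(C)C)c3)c(F)c2)c(OC)c1` gives 1680 nM in a functional assay on MKN-45 cells (Homo sapiens) for cytotoxicity, read by MTT assay, with a stated time of 72 h; on this read-out higher numbers stand for weaker inhibition and lower numbers for stronger inhibition.
Compound 2 `COc1ccc(/C=N/NC(=O)Nc2ccc(Oc3ccnc(-c4nncn4CCN(C)C)c3)c(F)c2)c(OC)c1OC` gives 2020 nM in this assay.
Compound 3 `CN(C)CCn1cnnc1-c1cc(Oc2ccc(NC(=O)N/N=C/c3cc(Br)c(O)c(Br)c3)cc2F)ccn1` gives 4320 nM in this assay.

Compound 2 stands second highest of the three numbers. Its nearest neighbour is compound 1, the step of a 1.2-fold higher number from compound 1 to compound 2 (0.08 log units; within the scatter) lying within the scatter, so the two cannot be told apart. Its furthest is compound 3, reached by a 2.1-fold higher number from compound 2 to compound 3 (0.33 log units; beyond the scatter), a modest step beyond the scatter.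

Compound 4 `CN(C)CCn1cnnc1-c1cc(Oc2ccc(NC(=O)N/N=C/c3cccc(O)c3)cc2F)ccn1` has not been measured in this assay. It differs from compound 2 in one place: 3-hydroxyphenyl in place of 2,3,4-trimethoxyphenyl on a carbon with a double bond to nitrogen.

Going by the values given here, two measured steps bear on this change, both replacing a methoxy-bearing ring on the carbon double-bonded to nitrogen with a hydroxyl-bearing one: a 2.1-fold higher number from compound 2 to compound 3 (0.33 log units; beyond the scatter) and a 2.6-fold higher number from compound 1 to compound 3 (0.41 log units; beyond the scatter). Both are modest rises in the number. The group entering compound 4 carries a hydroxyl like the ring in compound 3 but no bromines, so the data give no exact match. A modest rise in the number, close to that seen for compound 3, or a step within the scatter, is therefore expected.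

Compound 4 is estimated at 3200 nM in this assay, in a range from 1500 nM to 7000 nM, meaning an expected step of a 1.6-fold higher number from compound 2 to compound 4 (0.20 log units; within the scatter).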

Compound 4, half-maximal inhibitory concentration: 1370 nM
For compound 4 the middle estimate is 2.3-fold (0.37 log units) above the measured one; measured number below the stated range.
By their numbers in this assay, from the lowest: compounds 4, 1 and 2 (each within the scatter of the next); then compound 3.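

In this assay, going by these compounds alone, the ring on the carbon with a double bond to nitrogen can give up all of its methoxy groups for a single hydroxyl with no step that can be read: the two comparisons (a 1.5-fold lower number from compound 2 to compound 4 (0.17 log units; within the scatter); a 1.2-fold lower number from compound 1 to compound 4 (0.09 log units; within the scatter)) both stay within the scatter, so 3-hydroxyphenyl cannot be told apart from 2,3,4-trimethoxyphenyl or 2,4-dimethoxyphenyl here. Until now, the only hydroxyl-bearing ring at this position was 3,5-dibromo-4-hydroxyphenyl, which gave a higher number than both methoxy rings, and the new result (a 3.2-fold lower number from compound 3 to compound 4 (0.50 log units; beyond the scatter)) shows that a hydroxyl on this ring does not by itself go with that higher number. The modest step beyond the scatter belongs to the whole 3,5-dibromo-4-hydroxyphenyl group, and nothing shown here gives a reason for it.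

From the compounds shown here alone, the bromines and the place of the hydroxyl change together in that step, so the share of each stays open. Also open, going by these compounds, is how a plain phenyl ring, or an amine or a carboxylic acid in place of the hydroxyl, would read at this position.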